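The source may hold more compounds than are shown below. What is called first, only, known or untested is meant among the compounds shown, and "the series" means these compounds.

Working notes on the series.

Three compounds have numbers in an assay on CHO cells for displacement of a labelled ligand from 5-hydroxytryptamine receptor 7 (Homo sapiens); on this read-out higher numbers stand for weaker inhibition and lower numbers for stronger inhibition. Compound 1 `CCC1(CCCCN2CCN(c3cccc(Cl)c3)CC2)C(=O)Nc2c(Cl)cc(Cl)cc21` gives 9.46 nM. Compound 2 `CCC1(CCCCN2CCN(c3ccccc3)CC2)C(=O)Nc2ccccc21` gives 2.07 nM. Compound 3 `CCC1(CCCCN2CCN(c3ccc(Cl)cc3)CC2)C(=O)Nc2c(Cl)cc(F)cc21` gives 5.97 nM. Compound 2 stands lowest of the three; the gap to compound 3 and the gap to compound 1 are both beyond the scatter. For the measured compounds named here, compounds 1 and 3 differ from compound 2 in more than one place, so no single step between measured compounds can be read off.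

Compound 4 `CCC1(CCCCN2CCN(c3ccc(Cl)c(Cl)c3)CC2)C(=O)Nc2ccccc21` is not yet measured. It differs from compound 2 in one place: 3,4-dichlorophenyl in place of phenyl on an amine nitrogen in a ring. Going by the values given here, no measured pair shows this change on its own. Compounds 1 and 3, which each carry a chlorine on the phenyl together with changes on the shared core, both stand above compound 2 in this assay, and that is the only hint available. A modest rise, within or just beyond the scatter, is therefore expected, and the step from compound 2 to compound 4 is estimated at a 1.9-fold higher number from compound 2 to compound 4 (0.29 log units; within the scatter). For compound 4 the expected value is 4 nM, with a range from 1.5 nM to 12 nM.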

Compound 4, inhibition constant: 0.63 nM
The estimate for compound 4 lay 6.3-fold (0.80 log units) above the measured number, outside the stated range (below it).
By their numbers in this assay, from the lowest: compound 4; then compound 2; then compounds 3 and 1 (each within the scatter of the next).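

In this assay, for the compounds shown here, 3,4-dichlorophenyl in place of phenyl on an amine nitrogen in a ring gives a 3.3-fold lower number from compound 2 to compound 4 (0.52 log units; beyond the scatter) and this modest step is the first single change that can be read. It shows that this position accepts the two added chlorines with the number going down rather than up, so a higher number does not follow from chlorine on this phenyl in the setting of compound 2. Steps to compounds 1 and 3 cannot be read, as each differs from the others in more than one place, and no measurement at hand bears on the reason for the step from compound 2 to compound 4.

As far as these compounds go, it remains open whether both chlorines are needed, or whether a single chlorine on the phenyl would do the same on the core of compound 2. Also open, from the compounds shown here alone, are how a methoxy or trifluoromethyl group would compare on this phenyl and whether the step holds on a core carrying halogens, as in compounds 1 and 3.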